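Replacing the Ethoxycarbonyl Group of Compound 3

The source may hold more compounds than are shown below. What is called first, only, known or untested is meant among the compounds shown, and "the series" means these compounds.

Of the compounds shown here, three sharing one core have been measured in an assay on microsomes from brain for inhibition of Fatty-acid amide hydrolase 1 (Rattus norvegicus), read by fluorescence and HPLC, with a stated time of 60 min; on this read-out higher numbers stand for weaker inhibition and lower numbers for stronger inhibition. Compound 1 `CCCCCCCCc1ccc(OCC(=O)Cn2nnnc2C)cc1` gives 41 nM, compound 2 `CCCCCCCCc1ccc(OCC(=O)Cn2nnnc2Cc2ccccc2)cc1` gives 320 nM, and compound 3 `CCCCCCCCc1ccc(OCC(=O)Cn2nnnc2C(=O)OCC)cc1` gives 940 nM. Compound 3 therefore stands at the highest number of the three, with its steps to both neighbours beyond the scatter: a 23-fold higher number from compound 1 to compound 3 (1.36 log units; beyond the scatter) and a 2.9-fold higher number from compound 2 to compound 3 (0.47 log units; beyond the scatter).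

Compound 4 `CCCCCCCCc1ccc(OCC(=O)Cn2nnnc2-c2ccc(C(=O)O)cc2)cc1` differs from compound 3 in one place: 4-carboxyphenyl in place of ethoxycarbonyl on an aromatic carbon. Within the data shown here, no measured step replaces one group on that aromatic carbon by a carboxyphenyl, so the bearing steps are indirect. The step of a 7.8-fold higher number from compound 1 to compound 2 (0.89 log units; beyond the scatter) shows that a phenyl ring added at that end of the molecule raised the number; the step of a 2.9-fold higher number from compound 2 to compound 3 (0.47 log units; beyond the scatter) shows that the ethoxycarbonyl raised it further. Compound 4 carries both an aromatic ring and a carboxylic acid at this position, larger than anything measured here. The step is expected to be modest, toward a higher number, as a 1.6-fold higher number from compound 3 to compound 4 (0.20 log units; within the scatter), though the direction is uncertain given the lack of a directly comparable pair. Compound 4 is therefore estimated at 1500 nM, with a range from 300 nM to 8000 nM.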

Compound 4, half-maximal inhibitory concentration: 3400 nM
The estimate for compound 4 lay 2.3-fold (0.36 log units) below the measured number; low and high end bracket the measured number.
By their numbers in this assay, from the lowest: compound 1; then compound 2; then compound 3; then compound 4.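

In this assay, the carbon between two ring nitrogen atoms tolerates the 4-carboxyphenyl group less well than any other group seen there, with a 3.6-fold higher number from compound 3 to compound 4 (0.56 log units; beyond the scatter), an 11-fold higher number from compound 2 to compound 4 (1.03 log units; beyond the scatter) and an 83-fold higher number from compound 1 to compound 4 (1.92 log units; beyond the scatter), all beyond the scatter, so compound 4 is the weakest inhibitor of the four. The change from ethoxycarbonyl brings in a six-membered aromatic ring and a hydrogen-bond donor, and it shows that a group combining a ring with a carboxylic acid does not restore any of the ground lost from compound 1, widening the span of numbers at this single position. Nothing given here explains why the number rises with this group.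

The compounds shown leave open whether the rise belongs to the ring or to the carboxylic acid, and a plain phenyl or a methyl ester in place of the carboxylic acid would separate the two. They also leave open whether hydrogen or an ethyl group at this carbon would give a number lower than that of compound 1, which so far holds the lowest number with its methyl group.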